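The source may report more compounds than this note shows. Statements on the series, on what has been measured and on what is new or still open speak of the compounds shown alone.

Measured so far:
compound 1 `CCCCn1c(=O)n(Cc2ccccc2F)c(=O)c2[nH]c(Cc3ccc(NS(=O)(=O)c4ccccc4)cc3)nc21`: 22%
compound 2 `CCCCn1c(=O)n(Cc2ccccc2F)c(=O)c2[nH]c(Cc3ccc(NS(=O)(=O)c4ccsc4C(=O)OC)cc3)nc21`: 19%

In an assay on isolated protein for inhibition of phosphoenolpyruvate carboxykinase, cytosolic [GTP] (Homo sapiens), tested at 1 uM (on this read-out higher numbers stand for more inhibition at the one concentration tested (going by the name of the read-out) and lower numbers for less inhibition), compound 2 gives 19%, the lowest of the two numbers; the nearest is compound 1 with 22%, and the step of a number 3 percentage points lower from compound 1 to compound 2 (within the scatter) lies within the scatter. Compound 3 `CCCCn1c(=O)n(Cc2ccccc2F)c(=O)c2[nH]c(Cc3ccc(NS(=O)(=O)c4cccs4)cc3)nc21` differs from compound 2 by thiophen-2-yl in place of 2-(methoxycarbonyl)thiophen-3-yl on a sulfonyl sulfur. For the measured compounds named here, the only measured step that touches the group on this sulfonyl sulfur is a number 3 percentage points lower from compound 1 to compound 2 (within the scatter), a small one, so no step beyond the scatter is expected in this assay. For compound 3 the estimate is 21%, with a range from 6% to 36%. The expected step of a number 2 percentage points higher from compound 2 to compound 3 (within the scatter) stays within the scatter.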

Compound 3, a percentage reported as inhibition, at one concentration (the size of the read-out at that concentration, not a potency): 30%
Compound 3: the middle estimate sits 9 percentage points below what was measured; measured number inside the range.
By their numbers in this assay, from the lowest: compounds 2, 1 and 3 (each within the scatter of the next, the first and the last beyond it).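

In this assay the group on the sulfonyl sulfur now moves the number beyond the scatter, with a number 11 percentage points higher from compound 2 to compound 3 (beyond the scatter) for a change that drops the methoxycarbonyl and also shifts the thiophene attachment. Set against phenyl, thiophen-2-yl shows a number 8 percentage points higher from compound 1 to compound 3 (within the scatter), so only the pair with 2-(methoxycarbonyl)thiophen-3-yl separates. Nothing on hand accounts for this step. The compounds shown do not separate the loss of the methoxycarbonyl from the shift in attachment. Also open, from the compounds shown here alone, is what an amine or a carboxylic acid on the thiophene ring would give.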